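Butyl-benzofuran ketones: methyl on a nitrogen-bearing carbon

This account rests on a few compounds, and the source may have more. Where it says the series, first, only, none or still open, it means among the compounds named here.

Measured compounds:
Compound 1 `CCCCc1oc2ccccc2c1C(=O)c1ccc(OCCCC(=O)NCc2ccccc2)cc1` gives 28900 nM in a functional assay on HL-60 cells (Homo sapiens) for antiproliferative activity, read by MTT assay, with a stated time of 24 h; on this read-out lower numbers stand for stronger inhibition and higher numbers for weaker inhibition.
Compound 2 `CCCCc1oc2ccccc2c1C(=O)c1ccc(OCCCC(=O)N[C@H](C)c2ccccc2)cc1` gives only the limit > 50000 nM in this assay.
Compound 3 `CCCCc1oc2ccccc2c1C(=O)c1cc(I)c(OCCCN2CCN(C)CC2)c(I)c1` gives only the limit > 50000 nM in this assay.

Compound 1 and compound 2 share one core; the step between them is methyl in place of hydrogen on a saturated chain carbon bound to an amide-type nitrogen and an aromatic carbon. In this assay that step reads an at least 1.7-fold higher number from compound 1 to compound 2 (0.23 log units; that floor lies within the scatter), so the number rises, but since the value of compound 2 is a limit and not a number, the true size of the step is open. Two of the three values sit at the limit of > 50000 nM in this assay, at which 2 of the 3 values shown sit.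

Compound 3 carries a different core, and the difference between the two cores is not broken down here. The unmeasured compound 4 `CCCCc1oc2ccccc2c1C(=O)c1cc(I)c(OCCCN2CCN(CC)CC2)c(I)c1` stands to compound 3 as compound 2 stands to compound 1: the change is methyl in place of hydrogen on a saturated chain carbon bound to an amine nitrogen in a ring. It is the same kind of change, not the same. The place differs: in compound 2 the carbon is bound to an amide-type nitrogen and an aromatic carbon, in compound 4 to an amine nitrogen in a ring.

In this assay the step from compound 3 to compound 4 is expected to be a step that the limit leaves unreadable from compound 3 to compound 4. That expectation rests on the starting point of compound 3 at > 50000 nM, already a limit, and on the earlier step of an at least 1.7-fold higher number from compound 1 to compound 2 (0.23 log units; that floor lies within the scatter), which did not lower the number. Compound 4 is therefore estimated at 70000 nM, between 30000 nM and 200000 nM, most likely reported as a limit again.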

Compound 4, half-maximal inhibitory concentration: 28500 nM
Beside the measured number, compound 4's estimate is 2.5-fold (0.39 log units) above it; the whole stated range lies above it.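

In this assay, methyl in place of hydrogen on a saturated chain carbon bound to an amine nitrogen in a ring gives an at least 1.7-fold lower number from compound 3 to compound 4 (0.24 log units; that floor lies within the scatter), and compound 4 is a measured number where compound 3 is only a limit. Carried from one core to the other, this kind of change therefore does not keep its direction, and the two steps stand apart by more than the scatter allows: the same change on two cores in this assay, an at least 1.7-fold higher number (0.23 log units; that floor lies within the scatter) from compound 1 to compound 2 and an at least 1.7-fold lower number (0.24 log units; that floor lies within the scatter) from compound 3 to compound 4, at least 3.0-fold (0.48 log units) apart, beyond the scatter of two such steps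

This does not give the true size of either step, as each has a limit at one end, and it does not separate the effect of the core from that of the place, since the carbon that takes the methyl also differs between the two pairs; the limit also leaves little room for reading the series as a whole: the limit of > 50000 nM in this assay, at which 2 of the 4 values shown sit.

Still open, as far as these compounds go, is whether the direction seen from compound 3 to compound 4 continues with a longer chain, such as propyl in place of the ethyl of the 4-ethylpiperazin-1-yl group, or ends there. Also open, from the compounds shown here alone, is how the 4-ethylpiperazin-1-yl and 4-methylpiperazin-1-yl groups read on the core of compound 1, a pair that would hold the core fixed while testing the same place.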